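The compounds below may be only part of what the source reports. "The series", "measured", "known", "first", "only" and "open" are said of these compounds alone.

Compound 2 `CC(C(=O)N1CCN(c2ccccc2F)CC1)N1C(=O)CCC1=O` gives 0% in a functional assay on the whole organism (strain Swiss) with Mus musculus as the target, in the maximal electroshock model, with a stated time of 0.5 h, at a dose of 100 mg/kg by the intraperitoneal route (a higher number here means a stronger effect of the compound at the dose given, a lower number a weaker effect), the lowest of the two numbers measured. Compound 1 `CC(C(=O)N1CCN(c2ccc(Cl)cc2)CC1)N1C(=O)CCC1=O` gives 25% in this assay. For the measured compounds named here, the only measured step, a number 25 percentage points lower from compound 1 to compound 2 (beyond the scatter), exchanges 4-chlorophenyl for 2-fluorophenyl and so bears only loosely on the present change. Compound 3 `CC(C(=O)N1CCN(c2ccc(F)cc2)CC1)N1C(=O)CCC1=O` differs from compound 2 by 4-fluorophenyl in place of 2-fluorophenyl on an amine nitrogen in a ring. Because compound 1 with 4-chlorophenyl gives 25%, a modest rise is expected for compound 3, though with wide uncertainty. Compound 3 is estimated at 15% in this assay, within 0% to 40%, an expected step of a number 15 percentage points higher from compound 2 to compound 3 (beyond the scatter).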

Compound 3, a percentage reported as activity, at one dose (the size of the read-out at that dose, not a potency): 0%
For compound 3 the middle estimate is 15 percentage points above the measured one, and the stated range covers the measured number.
By their numbers in this assay, from the lowest: compounds 2 and 3 (each within the scatter of the next); then compound 1.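

Shifting the fluorine around the ring gives no change at the digits printed from compound 2 to compound 3 (within the scatter), so in this assay 4-fluorophenyl and 2-fluorophenyl cannot be told apart at this dose. The halogen itself does matter at the 4-position, where fluoro in place of chloro gives a number 25 percentage points lower from compound 1 to compound 3 (beyond the scatter). Nothing available explains this difference between chloro and fluoro.

Open, from the compounds shown here alone, is whether 4-bromophenyl or 4-methoxyphenyl on the same amine nitrogen would match compound 1 or go beyond it. Also open, going by these compounds, is whether 2-chlorophenyl would keep any of that effect.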